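A few compounds are considered here, and "the series" means these few. Any claim that something is new, unique, unknown or untested is made for them only; others in the source may bear on it.

Of the compounds shown here, three sharing one core have been measured in an assay for inhibition of Amine oxidase [flavin-containing] B (Rattus norvegicus); on this read-out lower numbers stand for stronger inhibition and higher numbers for weaker inhibition. Compound 1 `COc1cccc(COc2ccc(C3=NN(CCC#N)C(=O)CO3)cc2)c1` gives 68 nM, compound 2 `Cc1ccc(COc2ccc(C3=NN(CCC#N)C(=O)CO3)cc2)cc1` gives 320 nM, and compound 3 `N#CCCN1N=C(c2ccc(OCc3cccc(Cl)c3)cc2)OCC1=O` gives 13 nM. Compound 3 stands lowest of the three, with compound 1 nearest and compound 2 furthest. The steps between them are all beyond the scatter: a 4.7-fold higher number from compound 1 to compound 2 (0.67 log units; beyond the scatter), a 5.2-fold lower number from compound 1 to compound 3 (0.72 log units; beyond the scatter), and a 25-fold lower number from compound 2 to compound 3 (1.39 log units; beyond the scatter).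

Compound 4 `N#CCCN1N=C(c2ccc(OCc3ccc([N+](=O)[O-])cc3)cc2)OCC1=O` differs from compound 3 in one place: 4-nitrophenyl in place of 3-chlorophenyl on a saturated chain carbon bound to an oxygen on an aromatic ring. For the measured compounds named here, no measured compound carries a nitro group, so the bearing of this change rests on the pattern across the three benzyl substituents. The step from compound 2 to compound 3 a 25-fold lower number from compound 2 to compound 3 (1.39 log units; beyond the scatter) is the one that most directly concerns a 4-substituted phenyl against a 3-substituted one, and the step from compound 1 to compound 2 a 4.7-fold higher number from compound 1 to compound 2 (0.67 log units; beyond the scatter) points the same way. Both were beyond the scatter, so for compound 4 a higher number than for compound 3 is expected, of a modest to large size, an 8.5-fold higher number from compound 3 to compound 4 (0.93 log units; beyond the scatter). The estimate for compound 4 in this assay is therefore 110 nM, expected to lie between 25 nM and 450 nM.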

Compound 4, half-maximal inhibitory concentration: 300 nM
Estimate against measurement, compound 4: 2.7-fold (0.44 log units) below; measured number inside the range.
By their numbers in this assay, from the lowest: compound 3; then compound 1; then compounds 4 and 2 (each within the scatter of the next).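

In this assay the 4-nitrophenyl group shows a 23-fold higher number from compound 3 to compound 4 (1.36 log units; beyond the scatter) as a large step and a 4.4-fold higher number from compound 1 to compound 4 (0.64 log units; beyond the scatter) as a modest one, so a second 4-substituted phenyl now stands well away from both 3-substituted phenyls. Nitro in place of methyl on an aromatic carbon gives a 1.1-fold lower number from compound 2 to compound 4 (0.03 log units; within the scatter) and is the only change at this position that stays within the scatter, so compound 2 and compound 4 cannot be told apart, and across the four compounds both carry higher numbers than compound 1 and compound 3, with none going against this pattern. Nothing available here accounts for these steps.

For the compounds shown here, no pair among the four carries the same group in both ring placements, so the effect of placement cannot be separated from the effect of the group itself, and the pattern rests on two compounds of each kind. Going by these compounds, how a plain phenyl, or a phenyl carrying an amine or a carboxylic acid, would read in this assay remains open, as does whether a longer chain in place of the saturated chain carbon would change the picture.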